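A few compounds are considered here, and "the series" means these few. Any claim that something is new, unique, unknown or untested is made for them only; others in the source may bear on it.

Series notes, amide variation on the shared core.

Compound 1 `Cc1noc(C)c1-c1cnc(N)c(Oc2ccc(C(=O)NC3CCCCC3)cc2)n1` is the reference point. In a functional assay on HeLa cells (Homo sapiens) for inhibition, read by MTT assay, with a stated time of 72 h (a higher number here means a weaker inhibitor, a lower number a stronger inhibitor), compound 1 gives 26100 nM. Among the measured compounds shown here, only one other compound has a number here: compound 2 `Cc1noc(C)c1-c1cnc(N)c(Oc2ccc(C(=O)Nc3cccc(Cl)n3)cc2)n1`, which carries 6-chloropyridin-2-yl on the amide-type nitrogen and gives 25500 nM in this assay. The two numbers sit together, as the step of a 1.0-fold lower number from compound 1 to compound 2 (0.01 log units; within the scatter) shows, so neither compound can be set apart from the other on the data in hand.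

Compound 3 `Cc1noc(C)c1-c1cnc(N)c(Oc2ccc(C(=O)Nc3cc(Cl)ccn3)cc2)n1` is not yet measured. Against compound 1 the change is 4-chloropyridin-2-yl in place of cyclohexyl on an amide-type nitrogen. For the measured compounds named here, the one step that bears on this is a 1.0-fold lower number from compound 1 to compound 2 (0.01 log units; within the scatter), where a chloropyridin-2-yl group also replaced cyclohexyl on the same amide-type nitrogen and left the number where it was. Going by the values given here, with that single comparison as the only guide, no step beyond the scatter is expected from compound 1 to compound 3 in this assay, an expected step of a 1.0-fold lower number from compound 1 to compound 3 (0.02 log units; within the scatter). For compound 3 the estimate in this assay is therefore 25000 nM, with a range from 11000 nM to 58000 nM, the width reflecting that a single step is thin support.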

Compound 3, half-maximal inhibitory concentration: 37900 nM
Estimate against measurement, compound 3: 1.5-fold (0.18 log units) below, within the range that was stated.
By their numbers in this assay, from the lowest: compounds 2, 1 and 3 (each within the scatter of the next).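

In this assay, the step of a 1.5-fold higher number from compound 1 to compound 3 (0.16 log units; within the scatter) shows that the result seen earlier with 6-chloropyridin-2-yl is not confined to that one group: a second chloropyridine on the amide-type nitrogen also leaves the number within the scatter of the cyclohexyl amide. Among the compounds shown here, the step of a 1.5-fold higher number from compound 2 to compound 3 (0.17 log units; within the scatter) adds a comparison the earlier compounds could not give, since it changes only where the chlorine sits on the pyridine ring, and this change also stays within the scatter. Compounds 1, 2 and 3 therefore cannot be ranked, and on these data neither replacing the six-membered carbon ring with a chloropyridine nor changing 6-chloropyridin-2-yl to 4-chloropyridin-2-yl separates them.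

Nothing in hand speaks to why these numbers sit together. Still open, going by these compounds, is whether any group on this nitrogen moves the number beyond the scatter, for instance a pyridin-2-yl without chlorine, a short chain ending in an amine or a carboxylic acid, or a methoxy group in place of the chlorine.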